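Phenyl for methoxy across a shared core

The source may report more compounds than this note shows. Statements on the series, on what has been measured and on what is new or still open speak of the compounds shown alone.

Compound 1 `COc1ccc(C(CC(=O)O)CC(=O)NNC(=O)c2cccc(NC(=N)N)c2)cc1` gives 1 in a physicochemical assay for lipophilicity (a lower number here means a more polar compound, a higher number a more lipophilic compound), and compound 2 `N=C(N)Nc1cccc(C(=O)NNC(=O)CC(CC(=O)O)c2ccc(-c3ccccc3)cc2)c1` gives 2.8; this is a number 1.80 log units higher from compound 1 to compound 2 (beyond the scatter), the change being (phenyl in place of methoxy on an aromatic carbon). Compound 3 `COc1ccc(C(CC(=O)O)CC(=O)NNC(=O)c2cccc(NC(C)=N)c2)cc1` gives 1.31, and the core of compound 3 differs from the core of compound 1 by methyl in place of amino on a carbon with a double bond to nitrogen, a change that made a number 0.31 log units higher from compound 1 to compound 3 (beyond the scatter). Compound 4 `CC(=N)Nc1cccc(C(=O)NNC(=O)CC(CC(=O)O)c2ccc(-c3ccccc3)cc2)c1` has not been measured. It differs from compound 3 by phenyl in place of methoxy on an aromatic carbon, the same change as that from compound 1 to compound 2, occurring twice among these compounds. Compound 4 is therefore expected to show a number 1.79 log units higher from compound 3 to compound 4 (beyond the scatter), a step of about the size seen earlier, because a number 1.80 log units higher from compound 1 to compound 2 (beyond the scatter). Compound 4 is estimated at 3.1, with a range from 2.7 to 3.5.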

Compound 4, partition coefficient: 3.11
For compound 4 the middle estimate is 0.01 log units below the measured one, and the stated range covers the measured number.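

In this assay phenyl in place of methoxy gives a number 1.80 log units higher from compound 3 to compound 4 (beyond the scatter) and so repeats in size the step of a number 1.80 log units higher from compound 1 to compound 2 (beyond the scatter) on the other core, while the second new step of a number 0.31 log units higher from compound 2 to compound 4 (beyond the scatter) likewise repeats a number 0.31 log units higher from compound 1 to compound 3 (beyond the scatter) and shows that the two changes add up across these four compounds. This is one pair of cores differing in one place, so it shows that the change carried over here but gives no general rule for the series. No measurement bears on why the step kept its size.

From the compounds shown here alone, whether the step holds when an amine or an ester stands in place of the carboxylic acid remains open. So does the outcome with a benzyl group or a chlorine on that aromatic carbon, or with a longer chain in the core.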